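Return to the benzamide with an added chloro substituent

The compounds below may be only part of what the source reports. "The series", "measured", "known", "first", "only" and "open" are said of these compounds alone.

Compound 1 `COc1cc(-c2nn(-c3cccc(NC(=O)c4cccc(C(F)(F)F)c4)c3)cc2-c2ccncc2)ccc1Cl` sits at the assay limit in a functional assay on SK-MEL-28 cells (Homo sapiens) for inhibition, read by sulforhodamine B assay, with a stated time of 48 h; on this read-out lower numbers stand for stronger inhibition of growth and higher numbers for weaker inhibition of growth: compound 1 gives > 50000 nM, a limit and not a number.
Compound 2 `COc1cc(-c2nn(-c3cccc(NC(=O)Nc4ccc(Cl)c(Cl)c4)c3)cc2-c2ccncc2)ccc1Cl` in this assay: compound 2 gives 7320 nM.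
Compound 3 `COc1cc(-c2nn(-c3cccc(NC(=O)Nc4cccc(C(F)(F)F)c4)c3)cc2-c2ccncc2)ccc1Cl` in this assay: compound 3 gives 3350 nM.

Compound 3 stands at the lowest of the two numbered values; the nearest numbered neighbour is separated by a 2.2-fold lower number from compound 2 to compound 3 (0.34 log units; beyond the scatter). Compound 4 `COc1cc(-c2nn(-c3cccc(NC(=O)c4ccc(Cl)c(C(F)(F)F)c4)c3)cc2-c2ccncc2)ccc1Cl` differs from compound 3 by 4-chloro-3-(trifluoromethyl)phenyl in place of (3-(trifluoromethyl)phenyl)amino on a carbonyl carbon. The step that bears on this most is an at least 14-fold lower number from compound 1 to compound 3 (1.17 log units; beyond the scatter), which undid the same amide-to-urea exchange in the other direction; an at least 6.8-fold lower number from compound 1 to compound 2 (0.83 log units; beyond the scatter) and a 2.2-fold lower number from compound 2 to compound 3 (0.34 log units; beyond the scatter) show the aryl swap itself mattering less. The expected outcome is therefore a clear rise, a 12-fold higher number from compound 3 to compound 4 (1.08 log units; beyond the scatter), possibly back to a limit. For compound 4 the estimate is 40000 nM, with a range from 10000 nM to 150000 nM.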

Compound 4, concentration for total growth inhibition: > 32500 nM
Compound 4 ended at the assay's limit (the forecaster's own chance of this, stated with the estimate: 55%); the middle value does not contradict the limit.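

In this assay, 4-chloro-3-(trifluoromethyl)phenyl on the carbonyl carbon in place of the urea arylamino groups gives an at least 9.7-fold higher number from compound 3 to compound 4 (0.98 log units; beyond the scatter) and an at least 4.4-fold higher number from compound 2 to compound 4 (0.64 log units; beyond the scatter). Compound 4 is a limit of the assay and not a number: the limit of > 32500 nM in this assay, at which 1 of the 4 values shown sits. The added chloro on the benzamide therefore does not recover the level of the ureas, while the step between the two benzamides cannot be read, both ends being limits.

Going by these compounds, whether the gain from the urea depends on its amide-type nitrogen hydrogen stays open. An N-methyl urea or a carbamate on the same aryl group would test this.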